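Extending the thioether chain by another two carbons

The source may hold more compounds than are shown below. What is called first, only, known or untested is meant among the compounds shown, and "the series" means these compounds.

Compound 1 `CCCCSC[C@H](NC(C)=O)C(=O)CCl` gives 41400 nM in a functional assay on NALM-6 cells (Homo sapiens); a lower number here means a stronger inhibitor, a higher number a weaker inhibitor. Compound 2 `CCCCCSC[C@H](NC(C)=O)C(=O)CCl` gives 5800 nM in this assay, and compound 3 `CCCCCCCSC[C@H](NC(C)=O)C(=O)CCl` gives 4800 nM in this assay. Compound 3 holds the lowest number of the three, though its gap to compound 2 lies within the scatter, whereas an 8.6-fold lower number from compound 1 to compound 3 (0.94 log units; beyond the scatter) lies well beyond it. Compound 4 `CCCCCCCCCSC[C@H](NC(C)=O)C(=O)CCl` differs from compound 3 by ethyl in place of hydrogen on a saturated chain carbon, seven bonds along the chain from a sulfur. Going by the values given here, the closest precedent is a 1.2-fold lower number from compound 2 to compound 3 (0.08 log units; within the scatter), which hardly moved the number, while a 7.1-fold lower number from compound 1 to compound 2 (0.85 log units; beyond the scatter) was the larger shift. Given a 1.2-fold lower number from compound 2 to compound 3 (0.08 log units; within the scatter), the step to compound 4 is expected to stay within the scatter in this assay, as a 1.2-fold lower number from compound 3 to compound 4 (0.08 log units; within the scatter). Compound 4 is therefore estimated at 4000 nM, between 1500 nM and 12000 nM.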

Compound 4, half-maximal inhibitory concentration: 7300 nM
Estimate against measurement, compound 4: 1.8-fold (0.26 log units) below, within the range that was stated.
By their numbers in this assay, from the lowest: compounds 3, 2 and 4 (each within the scatter of the next); then compound 1.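

With ethyl in place of hydrogen seven bonds along the chain from a sulfur, the result is a 1.5-fold higher number from compound 3 to compound 4 (0.18 log units; within the scatter) in this assay and, counted from the shorter chain, a 1.3-fold higher number from compound 2 to compound 4 (0.10 log units; within the scatter), so extension past compound 2 shows no gain through compound 4. The advantage over the shortest chain remains, as a 5.7-fold lower number from compound 1 to compound 4 (0.75 log units; beyond the scatter) shows. Nothing measured here explains this levelling.

A longer chain could stay level or turn weaker in this series. As far as these compounds go, an amine or a carboxylic acid on the chain remains open too.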